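Compound 3 and the limit reached across the series

This account rests on a few compounds, and the source may have more. Where it says the series, first, only, none or still open, it means among the compounds named here.

In a functional assay on BT-549 cells (Homo sapiens) for inhibition, read by sulforhodamine B assay, with a stated time of 48 h (on this read-out higher numbers stand for lower toxicity in this test and lower numbers for higher toxicity in this test), compound 1 (`COc1cc(-c2nn(-c3cccc(NC(=O)c4cccc(C(F)(F)F)c4)c3)cc2-c2ccncc2)ccc1Cl`) gives > 50000 nM as a limit of the assay and not as a number. Compound 2 (`COc1cc(-c2nn(-c3cccc(NC(=O)Nc4ccc(Cl)c(Cl)c4)c3)cc2-c2ccncc2)ccc1Cl`) likewise gives > 50000 nM as a limit of the assay and not as a number. Both readings sit at one limit (the limit of > 50000 nM in this assay, at which 2 of the 2 values shown sit) and compound 2 therefore cannot be ranked against compound 1. For the measured compounds named here, the one measured step (a step that the two limits leave unreadable from compound 1 to compound 2) offers no size to carry forward.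

Compound 3 (`COc1cc(-c2nn(-c3cccc(NC(=O)c4ccccc4)c3)cc2-c2ccncc2)ccc1Cl`) carries phenyl in place of (3,4-dichlorophenyl)amino on a carbonyl carbon. In this assay no step beyond the scatter is expected, in either direction, because compound 1 and compound 2 with different groups on this carbonyl carbon both sit at one limit (the limit of > 50000 nM in this assay, at which 2 of the 2 values shown sit). The expected step reads a number no higher from compound 2 to compound 3 (the limit leaves the size open) as an estimate only. For compound 3 the estimate is 50000 nM with an expected range from 25000 nM to 80000 nM and a report of a limit alone is the likeliest outcome.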

Compound 3, concentration lethal to 50% of the cells: > 100000 nM
Compound 3: only a limit was reported; the forecaster's own chance of this, stated with the estimate: 85%; middle value at least 2.0-fold (0.30 log units) from the limit.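

Compound 3 reads only as a limit of the assay, so no new step can be read between it and compound 1 or compound 2: the limit of > 100000 nM in this assay, at which 1 of the 3 values shown sits.

The compounds shown leave open how the groups on the carbonyl carbon rank against one another, as all three values are limits and none is a number.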